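The compounds below may be only part of what the source reports. "The series", "measured", "known", "first", "only" and "open" are said of these compounds alone.

Measured so far:
compound 1, `Cc1nc(S(C)(=O)=O)ccc1Oc1ncnc(OC2CCN(C(=O)OC(C)(C)C#N)CC2)c1F` — 92.9 nM
compound 2, `Cc1nc(S(C)(=O)=O)ccc1Oc1ncnc(OC2CCN(C(=O)SC3CC3)CC2)c1F` — 24.9 nM

In a functional assay on isolated protein for inhibition of Glucose-dependent insulinotropic receptor (Homo sapiens), read by HTRF and cAMP accumulation (on this read-out lower numbers stand for an effect already at smaller amounts and higher numbers for an effect only at larger amounts of compound), compound 2 gives 24.9 nM, the lowest of the two numbers. Compound 1 gives 92.9 nM in this assay, and the step of a 3.7-fold lower number from compound 1 to compound 2 (0.57 log units; beyond the scatter) lies beyond the scatter. Compound 3, `Cc1nc(S(C)(=O)=O)ccc1Oc1ncnc(OC2CCN(C(=O)SC3(C)CC3)CC2)c1F`, differs from compound 2 by methyl in place of hydrogen on a saturated ring carbon.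

Among the compounds with values here, no measured step bears directly on this change. Within the data shown here, the only step known, a 3.7-fold lower number from compound 1 to compound 2 (0.57 log units; beyond the scatter), replaces the whole group on the carbonyl carbon rather than adding a methyl to a ring carbon that is already there, so it gives no guide to the size or direction of the present step. The expectation therefore rests on compound 2 alone, and no step beyond the scatter is expected in this assay.

For compound 3 a value of 25 nM is expected in this assay, with a range from 8 nM to 80 nM. The expected step from compound 2 is a 1.0-fold higher number from compound 2 to compound 3 (0.00 log units; within the scatter), which would be within the scatter.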

Compound 3, half-maximal effective concentration: 13.2 nM
For compound 3 the middle estimate is 1.9-fold (0.28 log units) above the measured one; measured number inside the range.
By their numbers in this assay, from the lowest: compounds 3 and 2 (each within the scatter of the next); then compound 1.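

Methyl in place of hydrogen on a saturated ring carbon of the three-membered ring gives, in this assay, a 1.9-fold lower number from compound 2 to compound 3 (0.28 log units; within the scatter), so compound 2 and compound 3 cannot be told apart and this ring carbon accepts the change from cyclopropyl to 1-methylcyclopropyl without a step beyond the scatter. The group of compound 3 on the carbonyl carbon also stands clear of the group of compound 1, with a 7.0-fold lower number from compound 1 to compound 3 (0.85 log units; beyond the scatter) as the step between them. No measurement on the compounds shown accounts for either step.

As far as these compounds go, whether this ring carbon also accepts something larger than methyl, such as ethyl or trifluoromethyl, or a group bearing an amine, remains open. Also open, from the compounds shown here alone, is how 1-methylcyclopropyl behaves with oxygen in place of sulfur on the carbonyl carbon.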